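Phenyl on the amide-type nitrogen, compound 2 to compound 4

The source may hold more compounds than are shown below. What is called first, only, known or untested is meant among the compounds shown, and "the series" means these compounds.

In a functional assay on KB cells (Homo sapiens) for antiproliferative activity, read by MTT assay, with a stated time of 48 h (a lower number here means a stronger inhibitor, a higher number a weaker inhibitor), compound 2 (`Cn1cc(C2=C(c3nn(CCCn4cccc4)c4ncccc34)C(=O)NC2=O)c2ccccc21`) gives > 100000 nM as a limit and not a number. Compound 3 (`Cn1cc(C2=C(c3nn(CCCCn4ccnc4)c4ncccc34)C(=O)NC2=O)c2ccccc21`) gives > 100000 nM as a limit too. Evidence from the series is thin: the limit of > 100000 nM in this assay, at which 3 of the 3 values shown sit, is all that the measured compounds show. For the measured compounds named here, the one measured step, a step that the two limits leave unreadable from compound 2 to compound 3 and so gives no size to carry forward.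

Compound 4 (`Cn1cc(C2=C(c3nn(CCCn4cccc4)c4ncccc34)C(=O)N(c3ccccc3)C2=O)c2ccccc21`) differs from compound 2 by phenyl in place of hydrogen on an amide-type nitrogen in a ring and so has phenyl in place of hydrogen on an amide-type nitrogen in a ring. Going by the values given here, no measured step isolates this change. Compound 1 (`Cn1cc(C2=C(c3nn(CCCn4cncn4)c4ncccc34)C(=O)N(c3ccccc3)C2=O)c2ccccc21`) also carries phenyl on that amide-type nitrogen in a ring and gives > 100000 nM as a limit, so no gain in this assay is expected for compound 4. The expected change is a number no higher from compound 2 to compound 4 (the limit leaves the size open) as an estimate, with no step beyond the scatter in either direction. Compound 4 is estimated at 100000 nM with an expected range of 40000 nM to 200000 nM and will most probably be reported only as a limit.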

Compound 4, half-maximal inhibitory concentration: > 100000 nM
Compound 4: a limit, no number (the forecaster's own chance of this, stated with the estimate: 85%); the middle value sits exactly at the limit.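

Compound 4 gives > 100000 nM, a limit and not a number, so its steps from compound 1 and from compound 2 cannot be read. The compounds shown leave open whether phenyl on the amide-type nitrogen in a ring, or any change in the chain, alters antiproliferative activity at all.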